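Series notes: swapping the arylidene on compound 3

This account rests on a few compounds, and the source may have more. Where it says the series, first, only, none or still open, it means among the compounds named here.

Of the compounds shown here, three have been measured in a physicochemical assay for inhibition, read by colorimetric assay, tested at 1 mg/mL (on this read-out higher numbers stand for more inhibition at the one concentration tested (going by the name of the read-out) and lower numbers for less inhibition), so far. Compound 1 `CCN1C/C(=C\c2ccc(OC)cc2)C2=NN(C(N)=S)C(c3ccc(OC)cc3)C2C1` gives 88.2%. Compound 2 `COc1ccc(/C=C2\CCCc3c2nc(N)c(C#N)c3-c2ccc(OC)c(OC)c2)cc1OC` gives 9.73%. Compound 3 `COc1ccc(/C=C2\CCCC3C2=NN(C2=NC(=O)/C(=C/c4ccc(OC)c(OC)c4)S2)C3c2ccc(OC)cc2)cc1` gives 19.1%.

On these numbers compound 3 stands second highest of the three. Its nearest neighbour is compound 2, whose value lies within the scatter of that of compound 3, so no order between the two can be read. The furthest is compound 1, whose value lies well beyond the scatter above that of compound 3.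

The next compound to be measured in this assay is compound 4 `COc1ccc(/C=C2\CCCC3C2=NN(C2=NC(=O)/C(=C/c4ccc(Cl)cc4)S2)C3c2ccc(OC)cc2)cc1`. It differs from compound 3 in one place: 4-chlorophenyl in place of 3,4-dimethoxyphenyl on a double-bonded chain carbon bound to a double-bonded ring carbon. Among the compounds with values here, nothing among the measured compounds shows what such a swap does, since no pair measured so far differs only there.

Within the data shown here, with no comparable step to lean on, the expectation for compound 4 is a step of a number 0.9 percentage points higher from compound 3 to compound 4 (within the scatter), that is, no change beyond the scatter from compound 3. Compound 4 is therefore estimated at 20% in this assay, with a range from 8% to 35%.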

Compound 4, a percentage reported as inhibition, at one concentration (the size of the read-out at that concentration, not a potency): 25.7%
Estimate against measurement, compound 4: 5.7 percentage points below; the measured number falls inside the stated range.
By their numbers in this assay, from the lowest: compounds 2, 3 and 4 (each within the scatter of the next, the first and the last beyond it); then compound 1.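

In this assay, within the data shown here, a number 6.6 percentage points higher from compound 3 to compound 4 (within the scatter) gives the first one-place comparison, with 4-chlorophenyl in place of 3,4-dimethoxyphenyl on a double-bonded chain carbon bound to a double-bonded ring carbon. At this position, going from 10 heavy atoms and 2 hydrogen-bond acceptors in the group that leaves to 7 heavy atoms and 0 hydrogen-bond acceptors in the group that enters produces no change that can be read apart from the usual scatter, so this one swap gives no sign that the read-out depends on which of these two aryl groups sits there. No measurement on hand offers an explanation for this result.

Going by these compounds, what a group of another kind at this place would do remains open, for example a carboxylic acid or an amine on the phenyl ring, or a longer chain in place of the ring. No one-place step connects compound 1, at 88.2%, to this pair, so the compounds shown do not tie that value to any single structural difference.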